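Swapping the 3,5-difluorophenyl of compound 1 for cyclopentylamino

The compounds below may be only part of what the source reports. "The series", "measured", "known", "first", "only" and "open" are said of these compounds alone.

In a physicochemical assay for solubility (a lower number here means a less soluble compound, a higher number a more soluble compound), compound 1 (`CS(=O)(=O)c1ccc(-n2nc(C(F)F)c(C#N)c2-c2cc(F)cc(F)c2)nc1`) gives 50 ug/mL and compound 2 (`CC1CCCN(c2c(C#N)c(C(F)F)nn2-c2ccc(S(C)(=O)=O)cc2)C1`) gives 50 ug/mL, so the two stand level within the scatter. Compound 3 (`CS(=O)(=O)c1ccc(-n2nc(C(F)F)c(C#N)c2NC2CCCC2)nc1`) carries cyclopentylamino in place of 3,5-difluorophenyl on an aromatic carbon of the core of compound 1: cyclopentylamino in place of 3,5-difluorophenyl on an aromatic carbon. Among the measured compounds shown here, no measured pair shows a step of this kind, so the expectation is uncertain, and no change beyond the scatter is foreseen. The expected step is a 1.1-fold lower number from compound 1 to compound 3 (0.05 log units; within the scatter). Compound 3 is estimated at 45 ug/mL, with an expected range of 18 ug/mL to 70 ug/mL.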

Compound 3, solubility: 25 ug/mL
Estimate against measurement, compound 3: 1.8-fold (0.26 log units) above; the measured number falls inside the stated range.
By their numbers in this assay, from the lowest: compounds 3, 1 and 2 (each within the scatter of the next).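

In this assay, among the compounds shown here, the only step that can be read at this position, on an aromatic carbon of the shared core, is a 2.0-fold lower number from compound 1 to compound 3 (0.30 log units; within the scatter). The position therefore accepts cyclopentylamino, a non-aromatic ring with a hydrogen-bond donor, in place of 3,5-difluorophenyl, an aromatic ring without one, with no step beyond the scatter. Nothing shown gives a reason for this result. From the compounds shown here alone, whether an open-chain amine, morpholine or a carboxylic acid here would move this assay beyond the scatter remains open.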